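This account rests on a few compounds, and the source may have more. Where it says the series, first, only, none or still open, it means among the compounds named here.

Compound 1, `CCS(=O)(=O)Nc1cc(C2CCCCC2)cc2c1CCCC2c1c[nH]cn1`, gives 269 nM in an assay on isolated protein for binding affinity to Alpha-1A adrenergic receptor (Rattus norvegicus), read by radioligand binding; on this read-out lower numbers stand for stronger inhibition and higher numbers for weaker inhibition.
Compound 2, `CCS(=O)(=O)Nc1cccc2c1CCCC2c1c[nH]cn1`, gives 46.8 nM.
Compound 3, `CCS(=O)(=O)Nc1cccc2c1CCCC2c1c[nH]c(C)n1`, gives 794 nM.

Compound 2 stands lowest of these three numbers, with compound 1 nearer and compound 3 furthest. Compound 4, `CCS(=O)(=O)Nc1cc(F)cc2c1CCCC2c1c[nH]cn1`, differs from compound 2 by fluoro in place of hydrogen on an aromatic carbon. For the measured compounds named here, the step that bears most on this is a 5.7-fold lower number from compound 1 to compound 2 (0.76 log units; beyond the scatter), the one measured exchange of a group for hydrogen on an aromatic carbon; the step of a 17-fold higher number from compound 2 to compound 3 (1.23 log units; beyond the scatter) concerns a different part of the shared core. Since removing cyclohexyl gave a modest gain, adding a much smaller fluoro group is expected to move the number only a little, if at all. Compound 4 is therefore expected near 60 nM, between 25 nM and 150 nM, meaning a 1.3-fold higher number from compound 2 to compound 4 (0.11 log units; within the scatter).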

Compound 4, inhibition constant: 83.2 nM
Estimate against measurement, compound 4: 1.4-fold (0.14 log units) below; measured number inside the range.
By their numbers in this assay, from the lowest: compounds 2 and 4 (each within the scatter of the next); then compound 1; then compound 3.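

In this assay the aromatic carbon that holds cyclohexyl in compound 1 can also hold fluoro. With a 1.8-fold higher number from compound 2 to compound 4 (0.25 log units; within the scatter) the two compounds stand within the scatter of each other, so fluoro and hydrogen cannot be told apart here, while with a 3.2-fold lower number from compound 1 to compound 4 (0.51 log units; beyond the scatter) fluoro and cyclohexyl clearly differ at this same carbon. Nothing measured here gives a reason for either step. From the compounds shown here alone, whether chloro, methoxy or an amine at this carbon would read like fluoro or like cyclohexyl stays open. So does whether fluoro would give a similar result at another carbon of this ring.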